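Chloro substitution on the fused ring of compound 1

This account rests on a few compounds, and the source may have more. Where it says the series, first, only, none or still open, it means among the compounds named here.

Measured compounds:
compound 1 `O=S(=O)(CCC(F)(Cl)C(F)(F)Cl)c1nc2ccccc2s1` — 4500 nM
compound 2 `FC(F)=C(F)CCSc1ncc(-c2ccncc2)s1` — > 120000 nM
compound 3 `CC(C)(c1nccs1)C(C#N)C#N` — > 120000 nM

Going by the values given here, in a functional assay on HepG2 cells (Homo sapiens) for cytotoxicity, read by MTT assay, with a stated time of 48 h (a lower number here means a stronger inhibitor, a higher number a weaker inhibitor), compound 1 gives 4500 nM, the only numerical value among the three compounds. Compound 2 returns only a limit of the assay, > 120000 nM. Compound 3 likewise sits at a limit, > 120000 nM. Among the compounds with values here, compound 1 thus stands alone as the one compound with a measurable number, while the other two rest at the limit of > 120000 nM in this assay, at which 2 of the 3 values shown sit.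

Compound 4 `O=S(=O)(CCC(F)(Cl)C(F)(F)Cl)c1nc2ccc(Cl)cc2s1` has not yet been measured. It differs from compound 1 by chloro in place of hydrogen on an aromatic carbon, the new substituent sitting meta to a fused ring and para to a fused ring on the six-membered aromatic ring of carbon only, part of a fused or bridged system of two rings. Within the data shown here, no step between measured compounds is available to guide the size of this change.

In this assay the expected step from compound 1 to compound 4 is a 1.3-fold lower number from compound 1 to compound 4 (0.11 log units; within the scatter), a shift that should stay within the usual scatter, in either direction. On that basis compound 4 is estimated at 3500 nM, with a plausible range from 1200 nM to 10000 nM.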

Compound 4, half-maximal inhibitory concentration: 6100 nM
For compound 4 the middle estimate is 1.7-fold (0.24 log units) below the measured one; measured number inside the range.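

In this assay, chloro in place of hydrogen on an aromatic carbon, meta to a fused ring and para to a fused ring, gives a 1.4-fold higher number from compound 1 to compound 4 (0.13 log units; within the scatter), so at this position the added chlorine produces no change that can be told apart from the scatter. This is the first step shown in which a single place on the core of compound 1 is altered, and compound 4 keeps a measured number rather than a limit of the assay. Nothing measured in the data shown gives a reason for this result.

This single step leaves open whether a different group at the same position, such as an amine, a methoxy group or a carboxylic acid, would also stay within the scatter, and whether chloro would do so on the other carbons of that ring. It also leaves open how much the side chain of compound 1 contributes to the number, since no compound shown changes that chain while keeping the rest of the structure intact.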